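This account rests on a few compounds, and the source may have more. Where it says the series, first, only, none or still open, it means among the compounds named here.

Measured so far:
compound 1, `COc1cc(OC)cc(-n2cc(-c3ccc(OC)c(O)c3)nn2)c1`: > 10000 nM
compound 2, `COc1ccc(-n2cc(-c3ccc(OC)c(O)c3)nn2)c(OC)c1`: > 10000 nM

Both compounds were tested in a functional assay on MDA-MB-231 cells (Homo sapiens) for cytotoxicity, read by MTT assay; on this read-out lower numbers stand for stronger inhibition and higher numbers for weaker inhibition. For compound 1 the result is a limit of the assay rather than a number, > 10000 nM. For compound 2 the result is likewise only a limit, > 10000 nM. Compound 1 therefore stands nowhere above or below its companion on the numbers shown; both values sit at the limit of > 10000 nM in this assay, at which 2 of the 2 values shown sit, and no step between them can be read.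

Compound 3, `COc1ccc(-c2cn(-c3cc(OC)c(OC)c(OC)c3)nn2)cc1O`, has not been measured. It differs from compound 1 by methoxy in place of hydrogen on an aromatic carbon of a six-membered aromatic ring of carbon only, para to a large group. Within the data shown here, no step between measured compounds is available to size this change. With compound 1 at a limit and compound 2 at the same limit, the expected step of an at least 1.2-fold lower number from compound 1 to compound 3 (0.09 log units; that floor lies within the scatter) is none beyond the scatter, with the direction open. Compound 3 is thus expected to give 8000 nM in this assay, estimated to fall between 1500 nM and 30000 nM.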

Compound 3, half-maximal inhibitory concentration: > 10000 nM
Compound 3 gave a limit, no number; the forecaster's own chance of this, stated with the estimate: 60%; at least 1.2-fold (0.09 log units) between middle value and limit.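

Among these compounds, compound 3, like compound 1, gave only a limit in this assay, so no step from compound 1 to compound 3 can be read, and the methoxy in place of hydrogen cannot be sized. What the compounds shown leave open is how strongly any of them acts, since all end at one limit: the limit of > 10000 nM in this assay, at which 3 of the 3 values shown sit.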